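Nitro for Chloro on the Anilino Ring: Cytotoxicity Outlook

This account rests on a few compounds, and the source may have more. Where it says the series, first, only, none or still open, it means among the compounds named here.

Compound 1 `FC(F)(F)c1ccc(CSc2nc(Nc3cccc(Cl)c3)c3ccccc3n2)cc1` gives 18000 nM in a functional assay on MDA-MB-231 cells (Homo sapiens) for cytotoxicity, read by MTT assay, with a stated time of 72 h; a higher number here means a weaker inhibitor, a lower number a stronger inhibitor. Compound 2 `O=[N+]([O-])c1cccc(Nc2nc(SCc3ccc(C(F)(F)F)cc3)nc3ccccc23)c1` carries nitro in place of chloro on an aromatic carbon, and in this assay compound 2 gives 31500 nM, a step of a 1.8-fold higher number from compound 1 to compound 2 (0.24 log units; within the scatter). Compound 3 `FC(F)(F)c1ccc(CSc2nc(Nc3ccc(Cl)cc3)c3ccccc3n2)cc1` differs from compound 1 in 4-chlorophenyl in place of 3-chlorophenyl on a nitrogen on an aromatic ring; in this assay compound 3 gives 15100 nM, with steps of a 1.2-fold lower number from compound 1 to compound 3 (0.08 log units; within the scatter) and a 2.1-fold lower number from compound 2 to compound 3 (0.32 log units; beyond the scatter). Compound 4 `O=[N+]([O-])c1ccc(Nc2nc(SCc3ccc(C(F)(F)F)cc3)nc3ccccc23)cc1` is not yet measured and differs from compound 3 by nitro in place of chloro on an aromatic carbon. This is the same kind of change as that seen between compound 1 and compound 2, but there the nitro sits meta to a large group, whereas here it sits para to a large group. The expected step, resting on the earlier 1.8-fold higher number from compound 1 to compound 2 (0.24 log units; within the scatter), is a 1.8-fold higher number from compound 3 to compound 4 (0.25 log units; within the scatter) in this assay. Compound 4 is therefore estimated at 27000 nM in this assay, between 12000 nM and 60000 nM.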

Compound 4, half-maximal inhibitory concentration: 8670 nM
Estimate against measurement, compound 4: 3.1-fold (0.49 log units) above, outside the stated range (below it).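

In this assay, nitro in place of chloro does not carry over from one core to the other as a fixed step, and the two steps differ: the same change on two cores in this assay, a 1.8-fold higher number (0.24 log units; within the scatter) from compound 1 to compound 2 and a 1.7-fold lower number (0.24 log units; within the scatter) from compound 3 to compound 4, 3.0-fold (0.48 log units) apart, beyond the scatter of two such steps Moving to the 4-nitrophenyl group gives a 3.6-fold lower number from compound 2 to compound 4 (0.56 log units; beyond the scatter) and a 2.1-fold lower number from compound 1 to compound 4 (0.32 log units; beyond the scatter), both beyond the scatter, whereas a 1.7-fold lower number from compound 3 to compound 4 (0.24 log units; within the scatter) stays within it. Among the compounds shown here, this shows only that the step depends on the core in this one pair; each step alone lies within the scatter, so it shows neither a reason for the gap nor how the change would behave on any further core.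

As far as these compounds go, whether an amine or a carboxylic acid in place of the nitro would follow compound 4 or compound 2 stays open. All four compounds also keep the same trifluoromethyl group, so what a nitrile there would do is open too.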